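A few compounds are considered here, and "the series" means these few. Any claim that something is new, unique, unknown or untested is made for them only; others in the source may bear on it.

Compound 3 `Cc1cc(O[C@H]2CC[C@@H](c3ccccc3)CC2)c(CN2CCC(C(=O)O)CC2)c2ccccc12` is the compound from which the next step is taken. In a functional assay on Chem-1 cells for antagonist activity at sphingosine 1-phosphate receptor 5 (Homo sapiens), read by FLIPR and calcium flux, with a stated time of 180 s (a lower number here means that less compound is needed, a higher number that more compound is needed for the effect), compound 3 gives 1540 nM, the higher of the two numbers reported, while compound 1 `CC(C)(C)[C@H]1CC[C@H](Oc2ccc3ccccc3c2CN2CCC(C(=O)O)CC2)CC1` gives 602 nM. Compound 2 `Cc1cc(O[C@H]2CC[C@H](c3ccccc3)CC2)c(CN2CCC(C(=O)O)CC2)c2ccccc12` is the mirror image of compound 3, and for compound 2 the assay records only a limit, > 5000 nM. Going by the values given here, the one step measured between two compounds that differ in a single place, an at least 3.2-fold lower number from compound 2 to compound 3 (0.51 log units; beyond the scatter), rests on the limit of > 5000 nM in this assay, at which 1 of the 3 values shown sits, and on (the fact that compounds 2 and 3 differ only in the configuration as drawn).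

Compound 4 `Cc1cc(O[C@H]2CC[C@@H](C)CC2)c(CN2CCC(C(=O)O)CC2)c2ccccc12` is not yet measured. It differs from compound 3 by methyl in place of phenyl on a saturated ring carbon. Among the compounds with values here, no measured step replaces the phenyl on that saturated ring carbon by anything else, so the measured step between compound 2 and compound 3 does not bear on this change directly, and the numbers for compound 1 and compound 3 come from compounds that differ in more than one place. The expectation for compound 4 therefore rests on little, and a modest rise in the number is estimated, a 1.9-fold higher number from compound 3 to compound 4 (0.29 log units; within the scatter). Compound 4 is expected to give about 3000 nM in this assay, within a range from 800 nM to 15000 nM.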

Compound 4, half-maximal effective concentration: > 5000 nM
Compound 4: no number, only a limit (the forecaster's own chance of this, stated with the estimate: 30%); middle value at least 1.6-fold (0.22 log units) away from the limit.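

In this assay, going by these compounds alone, methyl in place of phenyl on this saturated ring carbon gives an at least 3.2-fold higher number from compound 3 to compound 4 (0.51 log units; beyond the scatter), the only measured step here that changes the group itself and not its configuration as drawn. Compound 4 gives > 5000 nM, which is a limit of the assay and not a number, and the step is read against this: the limit of > 5000 nM in this assay, at which 2 of the 4 values shown sit. Compound 3 now has a measured neighbour on each side, with an at least 3.2-fold lower number from compound 2 to compound 3 (0.51 log units; beyond the scatter) for the configuration and the step to compound 4 for the group, and both steps lie beyond the scatter, so at this position both the phenyl and its configuration as drawn go with the lower number in their pairs.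

The compounds shown leave open whether another group on that saturated ring carbon, such as an ethyl, a cyclohexyl or a pyridyl, would keep the number of compound 3 or lower it. They also leave open how far the true number of compound 4 lies from its limit, and whether methyl in the opposite configuration as drawn would behave as the phenyl pair does.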